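The source may hold more compounds than are shown below. What is called first, only, known or untested is meant among the compounds shown, and "the series" means these compounds.

Measured compounds in this series:

- compound 1, `C=CCn1c(=O)n([C@@H]2O[C@H](CO)[C@H]3OC(CCC)(CCC)O[C@H]32)c2nc(N)nc(O)c21`: 4 uM
- compound 2, `CCOC(=O)Cn1c(=O)n(C2OC(CO)[C@@H](O)[C@H]2O)c2nc(N)nc(O)c21`: 48 uM
- compound 3, `C=CCSc1nc2c(O)nc(N)nc2n1C1OC(CO)[C@@H](O)[C@H]1O`: 107 uM

All three were run in a functional assay (B cells) with Mus musculus as the target; a higher number here means that more compound is needed for the effect, a lower number that less compound is needed. Compound 2 stands second highest of the three numbers: its neighbour is compound 3, which gives a higher number, beyond the scatter, and furthest from it is compound 1, which gives a much lower number, also beyond the scatter. No pair of these compounds differs in a single place, so no measured step is available to anchor the change that follows.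

Compound 4, `Nc1nc(O)c2c(n1)n(C1OC(CO)[C@@H](O)[C@H]1O)c(=O)n2Cc1ccccc1`, is the next analogue to be measured in this assay. It is drawn from compound 2 by phenyl in place of ethoxycarbonyl on a saturated chain carbon bound to an aromatic nitrogen. With no measured step of this kind in hand, the direction is judged from the spread of the three numbers, which all fall within a broad band and point to a change that is moderate rather than large. The expected step is a 1.9-fold lower number from compound 2 to compound 4 (0.28 log units; within the scatter), toward a somewhat lower number, but with wide uncertainty. Compound 4 is therefore estimated at 25 uM, within a range of 6 uM to 100 uM.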

Compound 4, concentration for half-maximal effect: 6 uM
The estimate for compound 4 lay 4.2-fold (0.62 log units) above the measured number; the range from low to high includes it.
By their numbers in this assay, from the lowest: compounds 1 and 4 (each within the scatter of the next); then compound 2; then compound 3.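

In this assay, for the compounds shown here, phenyl in place of ethoxycarbonyl on a saturated chain carbon bound to an aromatic nitrogen gives an 8.0-fold lower number from compound 2 to compound 4 (0.90 log units; beyond the scatter) and supplies the first single-place step. This position therefore responds to the group it carries, with the step lying beyond the scatter. Phenyl brings an aromatic ring and no hydrogen-bond acceptors, ethoxycarbonyl brings hydrogen-bond acceptors and no ring, and no measurement at hand bears on which of these differences matters.

The compounds shown leave open whether the aromatic ring itself is needed, a question that cyclohexyl, pyridyl or a carboxylic acid on the same carbon would address. On these data alone, it also remains open whether the same change gives a similar step on the core of compound 1.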